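A few compounds are considered here, and "the series" means these few. Any claim that something is new, unique, unknown or untested is made for them only; others in the source may bear on it.

Of the compounds shown here, three sharing one core have been measured in a functional assay on BCG823 cells (Homo sapiens) for inhibition, read by MTT assay, with a stated time of 72 h; a higher number here means a weaker inhibitor, a lower number a stronger inhibitor. Compound 1 `CN(C(=O)NC(=O)c1ccc(F)c(F)c1)c1nc(C(F)(F)F)c(C(=O)N/N=C/c2ccc(C(F)(F)F)cc2)s1` gives 3.85 ug/mL. Compound 2 `CN(C(=O)NC(=O)c1cccc(C(F)(F)F)c1)c1nc(C(F)(F)F)c(C(=O)N/N=C/c2ccc(C(F)(F)F)cc2)s1` gives 4.22 ug/mL, and the step of a 1.1-fold higher number from compound 1 to compound 2 (0.04 log units; within the scatter) shows that exchanging the group on the carbonyl carbon at that end of the molecule hardly moved the number. Compound 3 `CN(C(=O)NC(=O)c1ccccc1F)c1nc(C(F)(F)F)c(C(=O)N/N=C/c2cccc(C(F)(F)F)c2)s1` gives 16.3 ug/mL, the highest of the three numbers, so it is the weakest inhibitor here by a margin beyond the scatter against both compound 1 and compound 2.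

Compound 4 `CN(C(=O)NC(=O)c1ccccc1F)c1nc(C(F)(F)F)c(C(=O)N/N=C/c2ccc(C(F)(F)F)cc2)s1` is built from the same atoms as compound 3, joined differently: 4-(trifluoromethyl)phenyl in place of 3-(trifluoromethyl)phenyl on a carbon with a double bond to nitrogen. Among the measured compounds shown here, no measured step touches this position, so no direct guide exists. For the measured compounds named here, what the numbers do show is that compound 1 and compound 2, which both carry the 4-(trifluoromethyl)phenyl group on that carbon, sit well below compound 3, while the one measured change at the other end of the molecule was small. On that basis compound 4 is expected to give a lower number than compound 3, a step of a 2.7-fold lower number from compound 3 to compound 4 (0.43 log units; beyond the scatter), though it may not reach compound 1 and compound 2. Compound 4 is estimated at 6 ug/mL in this assay, with a range from 3 ug/mL to 13 ug/mL.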

Compound 4, half-maximal inhibitory concentration: 3.87 ug/mL
The estimate for compound 4 lay 1.6-fold (0.19 log units) above the measured number; the measured number falls inside the stated range.
By their numbers in this assay, from the lowest: compounds 1, 4 and 2 (each within the scatter of the next); then compound 3.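

Among the compounds shown here, exchanging 3-(trifluoromethyl)phenyl for 4-(trifluoromethyl)phenyl on the carbon with a double bond to nitrogen gives the first direct measurement of this position in this assay and, with the atoms unchanged, a 4.2-fold lower number from compound 3 to compound 4 (0.62 log units; beyond the scatter) is a step beyond the scatter. With 4-(trifluoromethyl)phenyl held on that carbon, the group on the carbonyl carbon can be 2-fluorophenyl, 3-(trifluoromethyl)phenyl or 3,4-difluorophenyl without a difference beyond the scatter, as a 1.1-fold lower number from compound 2 to compound 4 (0.04 log units; within the scatter) and a 1.0-fold higher number from compound 1 to compound 4 (0.00 log units; within the scatter) both show, so these three compounds form one level and compound 3 alone stands apart from it. Nothing available here shows why the two arrangements of the same atoms differ in this way.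

Among the compounds shown, 3-(trifluoromethyl)phenyl on the carbon with a double bond to nitrogen occurs only together with 2-fluorophenyl on the carbonyl carbon, so it remains open whether the same step would appear with 3,4-difluorophenyl or 3-(trifluoromethyl)phenyl there. Also open, from the compounds shown here alone, is how a plain phenyl group, a methoxyphenyl group or a group carrying a carboxylic acid would compare on that carbon.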